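This account rests on a few compounds, and the source may have more. Where it says the series, first, only, none or still open, it means among the compounds named here.

Measured in a functional assay on Caco-2 cells (Homo sapiens) for activation, read by fluorescence, tested at 10 uM; a lower number here means a stronger effect, a higher number a weaker effect of the compound at the concentration tested:
compound 1 `COc1cc(/C=C/C(=O)/C=C(/C=C/c2ccc(O)c(OC)c2)NCCO)ccc1O`: 96.6%
compound 2 `O=C(/C=C(/C=C/c1ccc(O)cc1)NCCCO)/C=C/c1ccc(O)cc1`: 91.7%
compound 3 `COCCNC(=C\C(=O)/C=C/c1ccc(O)c(OC)c1)/C=C/c1ccc(O)c(OC)c1`: 75.6%

Compound 2 stands second highest of the three numbers in this assay. Its nearest neighbour is compound 1, whose number is higher by an amount within the scatter, so no order between compound 2 and compound 1 can be read from these two values. Compound 3 lies furthest from compound 2, with a number lower beyond the scatter.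

Compound 4 `COCCCNC(=C\C(=O)/C=C/c1ccc(O)cc1)/C=C/c1ccc(O)cc1` has not yet been measured in this assay. Against compound 2 it shows one difference: methyl in place of hydrogen on an oxygen on a saturated carbon. One measured step in the series carries the same change on another pair, and there it gave a number 21 percentage points lower from compound 1 to compound 3 (beyond the scatter), a modest move towards a stronger effect in this assay. For the measured compounds named here, no other pair tests this change, so the expectation rests on that single step alone and is held with a wide range. On that basis compound 4 is expected to give 72% in this assay, with the estimate spanning 55% to 90%. The step this estimate means, a number 19.7 percentage points lower from compound 2 to compound 4 (beyond the scatter), is expected to run towards a lower number, beyond the scatter but without certainty that it matches the earlier step in size.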

Compound 4, a percentage reported as activity, at one concentration (the size of the read-out at that concentration, not a potency): 89%
For compound 4 the middle estimate is 17 percentage points below the measured one, within the range that was stated.
By their numbers in this assay, from the lowest: compound 3; then compounds 4, 2 and 1 (each within the scatter of the next).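

In this assay the step on this core reads a number 2.7 percentage points lower from compound 2 to compound 4 (within the scatter), so hydroxy to methoxy on the 3-carbon chain of compound 2 gives no readable change here. One earlier pair had carried this change with a clear move, but a second pair now shows that the size of the step does not hold from one core to the other: the same change on two cores in this assay, a number 21 percentage points lower (beyond the scatter) from compound 1 to compound 3 and a number 2.7 percentage points lower (within the scatter) from compound 2 to compound 4, 18.3 percentage points apart, beyond the scatter of two such steps For this series, the change can no longer be treated as a fixed increment that carries over between cores, and the earlier step on its own says nothing reliable about other members.

Two pairs cannot show which of the structural differences between them goes with the gap between the steps, and a pair that differs from these only in the core or only in the chain would be needed to separate those two. How this assay responds to an amine or a carboxylic acid in place of the hydroxy, or to a longer chain carrying the methoxy, stays open on the compounds shown.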